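Thiophen-2-yl in Place of Methoxyphenyl: Working Notes

The compounds below may be only part of what the source reports. "The series", "measured", "known", "first", "only" and "open" are said of these compounds alone.

Measured so far:
compound 1 `O=C(O)c1cccc(Cc2c(-c3ccc(Cl)cc3)nn3cc(Cl)ccc23)n1` — 1100 nM
compound 2 `COc1ccc(-c2nn3cc(Cl)ccc3c2Cc2cccc(C(=O)O)n2)cc1` — 5400 nM

Both numbers come from a functional assay on cells for antagonist activity at prostaglandin E2 receptor EP1 subtype (Rattus norvegicus), read by fluorescence and calcium flux, with a stated time of 60 s; on this read-out higher numbers stand for weaker inhibition and lower numbers for stronger inhibition. Within the data shown here, compound 2 stands at the higher of the two numbers; the single measured step, a 4.9-fold higher number from compound 1 to compound 2 (0.69 log units; beyond the scatter), separates it from compound 1 and lies beyond the scatter.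

Compound 3 `O=C(O)c1cccc(Cc2c(-c3cccs3)nn3cc(Cl)ccc23)n1` is not yet measured. It differs from compound 2 by the following exchange: thiophen-2-yl in place of 4-methoxyphenyl on an aromatic carbon. Among the measured compounds shown here, no measured step covers this exchange. For the measured compounds named here, the one step known, a 4.9-fold higher number from compound 1 to compound 2 (0.69 log units; beyond the scatter), concerns a different group at the same place and shows that an exchange there can shift the number modestly. Thiophen-2-yl is neither of the two groups already measured, so the expectation for compound 3 is set between the two measured numbers, nearer to compound 1 than to compound 2. Compound 3 is estimated at 2500 nM, within a range of 800 nM to 8000 nM. This expected value amounts to a 2.2-fold lower number from compound 2 to compound 3 (0.33 log units; beyond the scatter).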

Compound 3, half-maximal inhibitory concentration: 1100 nM
For compound 3 the middle estimate is 2.3-fold (0.36 log units) above the measured one; measured number inside the range.
By their numbers in this assay, from the lowest: compounds 1 and 3 (each within the scatter of the next); then compound 2.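

In this assay, among these compounds, thiophen-2-yl in place of 4-methoxyphenyl on this aromatic carbon gives a 4.9-fold lower number from compound 2 to compound 3 (0.69 log units; beyond the scatter), the first exchange at this place that involves a five-membered aromatic ring with 1 hetero atom. Thiophen-2-yl in place of 4-chlorophenyl gives no change at the digits printed from compound 1 to compound 3 (within the scatter), so a six-membered aromatic ring of carbon only is not needed here to hold the number seen with 4-chlorophenyl, and among the three compounds only the 4-methoxyphenyl of compound 2 stands apart. Nothing available accounts for this difference.

Going by these compounds, it remains open whether furan-2-yl or unsubstituted phenyl at this place would read with compound 1 and compound 3 or with compound 2. Also open, on these data alone, is how an amine or a longer alkyl chain would read there.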